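Fluoro in place of bromo: from compound 1 to compound 3

The source may hold more compounds than are shown below. What is called first, only, known or untested is meant among the compounds shown, and "the series" means these compounds.

Compound 1 `Brc1cccc(Nc2nc(-c3ccncc3)cs2)c1` is the starting point of this account. In a functional assay on RCC4 cells (Homo sapiens) for inhibition, read by XTT assay, with a stated time of 4 days (a lower number here means a stronger inhibitor, a higher number a weaker inhibitor), compound 1 gives 40700 nM, the only number shown for it; a further entry for compound 1 in this assay carries no single number. Among the compounds with values here, compound 2 `Cc1cccc(Nc2nc(-c3ccncc3C#CCCCO)cs2)c1` is the only other measured compound; in this assay compound 2 gives 6300 nM; 1120 nM (2 entries) across its several entries (the several entries of compound 2 in this assay, 6300 nM; 1120 nM (2 entries)). Within the data shown here, compound 1 and compound 2 differ in more than one place, so no single step between them is known, and their two values are simply what they show.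

Compound 3 `Fc1cccc(Nc2nc(-c3ccncc3)cs2)c1` is the unmeasured compound. It differs from compound 1 by one change: fluoro in place of bromo on an aromatic carbon. Among the measured compounds shown here, no step between measured compounds covers this change, so the expectation rests on compound 1 alone, with its value of 40700 nM in this assay. The step expected in this assay is a 1.2-fold higher number from compound 1 to compound 3 (0.09 log units; within the scatter), small and within the usual scatter, with no clear direction. Compound 3 is therefore estimated in this assay at 50000 nM, with a range from 15000 nM to 150000 nM.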

Compound 3, half-maximal inhibitory concentration: 40700 nM
Compound 3: middle estimate off by 1.2-fold (0.09 log units), on the high side; the measured number falls inside the stated range.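

With fluoro in place of bromo on an aromatic carbon, meta to a large group, the record shows no change at the digits printed from compound 1 to compound 3 (within the scatter) in this assay. Within the data shown here, this is the first single-place step, which until now offered only compounds differing in more than one place, and on the core of compound 1 it does not distinguish bromo from fluoro at this position. Nothing in the available evidence explains this result or bears on this particular exchange.

As far as these compounds go, the step covers only two halogens at one position on one core, so it remains open whether an amine, a methoxy group, a carboxylic acid or a longer chain at the same place would also leave the number unmoved. From the compounds shown here alone, it also remains open whether bromo and fluoro would read alike on a core carrying other changes, such as the chain found in compound 2, which gives 6300 nM; 1120 nM (2 entries) in this assay but differs from compound 1 and compound 3 in more than one place.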